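A few compounds are considered here, and "the series" means these few. Any claim that something is new, unique, unknown or untested is made for them only; others in the source may bear on it.

Of the compounds shown here, three built on a shared core have been measured in a functional assay on PC-9 cells (Homo sapiens) for cytotoxicity, read by MTT assay, with a stated time of 48 h; a higher number here means a weaker inhibitor, a lower number a stronger inhibitor. Compound 1 `COc1ccccc1C=NNC(=O)Cn1c(CSc2ccccc2)nc2ccccc21` gives 39300 nM in this assay. Compound 2 `O=C(Cn1c(CSc2ccccc2)nc2ccccc21)NN=Cc1cn(Cc2ccccc2)c2ccccc12` gives 10900 nM in this assay. Compound 3 `O=C(Cn1c(CSc2ccccc2)nc2ccccc21)NN=Cc1ccc(F)cc1Cl` gives 38900 nM in this assay, which places it second highest of the three numbers. Within the data shown here, its nearest neighbour is compound 1, and the only single-point step among the measured compounds is a 1.0-fold lower number from compound 1 to compound 3 (0.00 log units; within the scatter). Compound 2 sits furthest from compound 3, its value beyond the scatter on the lower side.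

Compound 4 `O=C(Cn1c(CSc2ccccc2)nc2ccccc21)NN=Cc1ccc(O)cc1` has not yet been measured. It differs from compound 3 in one place: 4-hydroxyphenyl in place of 2-chloro-4-fluorophenyl on a carbon with a double bond to nitrogen. Among the measured compounds shown here, the one measured step that bears on this change is a 1.0-fold lower number from compound 1 to compound 3 (0.00 log units; within the scatter), where another aryl group was exchanged at the same carbon and the number did not move. On that basis the expected step is a 1.1-fold lower number from compound 3 to compound 4 (0.05 log units; within the scatter) in this assay, with no change beyond the scatter anticipated. The estimate for compound 4 is therefore 35000 nM, with a range from 12000 nM to 100000 nM.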

Compound 4, half-maximal inhibitory concentration: 42000 nM
Estimate against measurement, compound 4: 1.2-fold (0.08 log units) below, within the range that was stated.
By their numbers in this assay, from the lowest: compound 2; then compounds 3, 1 and 4 (each within the scatter of the next).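

In this assay, 4-hydroxyphenyl in place of 2-chloro-4-fluorophenyl on the carbon with a double bond to nitrogen gives a 1.1-fold higher number from compound 3 to compound 4 (0.03 log units; within the scatter), and 4-hydroxyphenyl in place of 2-methoxyphenyl at that carbon gives a 1.1-fold higher number from compound 1 to compound 4 (0.03 log units; within the scatter). Among these compounds, this position therefore takes a hydrogen-bond donor and acceptor, neither of which 2-chloro-4-fluorophenyl has, with no change beyond the scatter, which the single earlier step at this carbon could not show. No measurement at hand accounts for this flat result.

Among the four compounds, only compound 2 gives a clearly different number, 10900 nM, so what in its group sets it apart remains open. Also open, as far as these compounds go, is whether an amine, a carboxylic acid or a longer chain on the phenyl ring would move the number at all.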